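Lengthening the Amine Chain on a Shared Core

The source may report more compounds than this note shows. Statements on the series, on what has been measured and on what is new or still open speak of the compounds shown alone.

Compound 1, `NCCCNc1c(C(=O)NCc2ccc(F)cc2)ncc2cccnc12`, gives > 10000 nM in a functional assay on HT-29 cells (Homo sapiens) for cytotoxicity, read by MTT assay, with a stated time of 72 h (a lower number here means a stronger inhibitor, a higher number a weaker inhibitor), which is a limit of the assay and not a number.
Compound 2, `CNCCCNc1c(C(=O)NCc2ccc(F)cc2)nc(Br)c2cccnc12`, gives > 10000 nM in this assay, likewise a limit of the assay.

Compound 2 therefore stands at the edge of what this assay can report, and compound 1 stands at the same edge: the limit of > 10000 nM in this assay, at which 2 of the 2 values shown sit. Among the measured compounds shown here, neither value is a number, so nothing can be said about an order between the two, and no pair of measured compounds here differs in only one place, so no measured step exists to lean on.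

Compound 3, `NCCCCCCNc1c(C(=O)NCc2ccc(F)cc2)nc(Br)c2cccnc12`, is the next compound and differs from compound 2 in one place: 3-aminopropyl in place of methylamino on a saturated chain carbon, three bonds along the chain from a nitrogen on an aromatic ring. For the measured compounds named here, with both measured values sitting at the limit and no measured step to set a scale, the expected change from compound 2 to compound 3 in this assay is none beyond the scatter, which is what a step that the limit leaves unreadable from compound 2 to compound 3 expresses. Compound 3 is thus estimated at 12000 nM, with a range from 3000 nM to 40000 nM, and is expected most likely to be reported once more as a limit rather than a number.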

Compound 3, half-maximal inhibitory concentration: 5000 nM
Compound 3: the middle estimate sits 2.4-fold (0.38 log units) above what was measured; the range from low to high includes it.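

In this assay compound 3 gives 5000 nM, the first value among the compounds shown that is a number and not a limit, so a compound on this shared core can be read within the range of the assay. Placing 3-aminopropyl in place of methylamino on a saturated chain carbon, three bonds along the chain from a nitrogen on an aromatic ring, gives an at least 2.0-fold lower number from compound 2 to compound 3 (0.30 log units; that floor lies within the scatter), which points towards a stronger compound with the longer chain but does not by itself establish a change beyond the scatter. The size of this step can be given only as a floor, because compound 2 sits at a limit of the assay: the limit of > 10000 nM in this assay, at which 2 of the 3 values shown sit.

The compounds shown leave open whether the longer chain or the unsubstituted amine at its end accounts for the step, a question that a methylamino end on the same long chain would address. They also leave open how the value would respond to a still longer chain, or to a carboxylic acid in place of the amine at the chain end.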